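From 2-oxopyrrolidin-1-yl to methylsulfanyl on the shared core

The compounds below may be only part of what the source reports. "The series", "measured", "known", "first", "only" and "open" are said of these compounds alone.

Within the data shown here, compound 2 `O=C1CCCN1Cc1ncnc2c1ncn2[C@@H]1O[C@H](CO)[C@@H](O)[C@H]1O` gives 45000 nM in a functional assay on Huh-7 cells (Homo sapiens) for cytotoxicity, read by MTT assay, with a stated time of 3 days (a lower number here means that less compound is tolerated, a higher number that more compound is tolerated), and holds the only true number so far. Compound 1 `[N-]=[N+]=NCc1ncnc2c1ncn2[C@@H]1O[C@H](CO)[C@@H](O)[C@H]1O` reads > 250000 nM in this assay and that reading is a limit of the assay, not a number. The next compound, compound 3 `CSCc1ncnc2c1ncn2[C@@H]1O[C@H](CO)[C@@H](O)[C@H]1O`, keeps the shared core and carries methylsulfanyl in place of 2-oxopyrrolidin-1-yl on a saturated chain carbon bound to an aromatic carbon. Among the measured compounds shown here, only one measured step bears on this change, and it sits at the same place: 2-oxopyrrolidin-1-yl replacing azido gave an at least 5.5-fold lower number from compound 1 to compound 2 (0.74 log units; beyond the scatter) and its size rests on a limit. For the measured compounds named here, compound 3 gives up the group that came with that lower number, although no measured step shows methylsulfanyl itself. A modest move towards a higher number in this assay is therefore expected, smaller than the measured step, and it is estimated as a 2.2-fold higher number from compound 2 to compound 3 (0.35 log units; beyond the scatter) (an expectation only). For compound 3 the estimated value is 100000 nM (range 25000 nM to 250000 nM).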

Compound 3, half-maximal cytotoxic concentration: > 100000 nM
Compound 3 gave a limit, no number (the forecaster's own chance of this, stated with the estimate: 25%); the middle value lies on the limit itself.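

Putting methylsulfanyl in place of 2-oxopyrrolidin-1-yl on a saturated chain carbon bound to an aromatic carbon gave an at least 2.2-fold higher number from compound 2 to compound 3 (0.34 log units; beyond the scatter) in this assay. Among these compounds, this adds a second comparison at the same place: compound 2, the one of the three compounds with a ring in this group, now stands beyond the scatter with a lower number than both compound 1 and compound 3, so the lower number goes with 2-oxopyrrolidin-1-yl and not with azido or methylsulfanyl. The value of compound 3, > 100000 nM, is a limit of the assay and not a number.

Compound 1 and compound 3 both read as limits, and the step between them cannot be read, so azido and methylsulfanyl cannot be ordered against each other. On these data alone, it also stays open whether the lower number of compound 2 goes with the ring of 2-oxopyrrolidin-1-yl or with its carbonyl, and an open-chain amide or a simple amine at this place would bear on that question.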